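High Hepatic Extraction Carried Through the Series

This account rests on a few compounds, and the source may have more. Where it says the series, first, only, none or still open, it means among the compounds named here.

Among the measured compounds shown here, compound 1, `Cc1cc(-c2ccncc2NC(=O)c2nc(-c3ccccc3F)ccc2N)cc(N)n1`, and compound 2, `Cc1cc(-c2ccncc2NC(=O)c2nc(-c3c(F)cccc3F)ccc2N)cc(N)n1`, are the two measured members. In an ADME assay on liver with Liver microsome (Rattus norvegicus) as the target, read by LC-MS, using microsomes, with a stated time of 30 min, tested at 1 uM (a lower number here means that the liver removes a smaller share, a higher number that the liver removes a larger share of the compound in one pass), compound 1 gives 0.95 and compound 2 gives 0.94; the step a number 0.010 lower from compound 1 to compound 2 (within the scatter) keeps the pair within the scatter, so compound 2 stands alongside compound 1 rather than apart from it, both near the top of the scale. Compound 3, `Cc1nc(N)cc(-c2ccncc2NC(=O)c2nc(-c3c(F)cccc3F)ccc2N)n1`, differs from compound 2 by 6-amino-2-methylpyrimidin-4-yl in place of 2-amino-6-methylpyridin-4-yl on an aromatic carbon. For the measured compounds named here, the single measured step concerns fluoro in place of hydrogen and does not touch the ring that is exchanged here, so no direct precedent exists; what the two values show is that the shared core is extensively removed in one pass whichever of the two measured aryl groups is present. The expected step a number 0.010 lower from compound 2 to compound 3 (within the scatter) for compound 3 is therefore none beyond the scatter. Compound 3 is estimated at 0.93 in this assay, within 0.84 to 0.98.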

Compound 3, hepatic extraction ratio: 0.82
Beside the measured number, compound 3's estimate is 0.11 above it; measured number outside the range, below it.
By their numbers in this assay, from the lowest: compound 3; then compounds 2 and 1 (each within the scatter of the next).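

Placing 6-amino-2-methylpyrimidin-4-yl in place of 2-amino-6-methylpyridin-4-yl, on an aromatic carbon opposite the ring nitrogen, gives a number 0.12 lower from compound 2 to compound 3 (beyond the scatter) in this assay, so this position moves the hepatic extraction ratio beyond the scatter, which the fluoro change between compound 1 and compound 2 does not. The exchange replaces a ring with 1 hetero atom by a ring with 2 hetero atoms, while the entering and leaving groups both carry an amino and a methyl group. Nothing available bears on the origin of this step.

Going by these compounds, whether the same exchange gives a similar step on compound 1, with one fluoro fewer, remains open. Also open, on these data alone, is how the number would respond if the methyl of 6-amino-2-methylpyrimidin-4-yl gave way to a trifluoromethyl group or a longer chain, or its amino group to a hydroxyl group.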